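A few compounds are considered here, and "the series" means these few. Any claim that something is new, unique, unknown or untested is made for them only; others in the source may bear on it.

Compound 2 `Oc1cccc(-c2cc(-c3ccccc3)nc(-c3ccc(Cl)cc3)c2)c1` and compound 1 `Oc1cccc(-c2cc(-c3ccncc3)nc(-c3cccc(Cl)c3)c2)c1` have both been run in an assay on isolated protein for inhibition of DNA topoisomerase 1 (Homo sapiens), with a stated time of 30 min, tested at 100 uM; on this read-out higher numbers stand for a stronger effect at the one concentration tested and lower numbers for a weaker effect. In this assay compound 2 gives 7.1% and compound 1 gives 0%, two numbers that lie within the scatter of each other, so neither can be read as the stronger. Compound 3 `Oc1cccc(-c2cc(-c3ccncc3)nc(-c3ccc(Cl)cc3)c2)c1` is not yet measured; it differs from compound 2 by pyridin-4-yl in place of phenyl on an aromatic carbon. For the measured compounds named here, no step between measured compounds is available for comparison, and on two such low readings nothing beyond the scatter is expected. The step of a number 4.1 percentage points lower from compound 2 to compound 3 (within the scatter) is therefore estimated to stay within the scatter. Compound 3 is expected to give about 3% in this assay, somewhere between -5% and 12%.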

Compound 3, a percentage reported as inhibition, at one concentration (the size of the read-out at that concentration, not a potency): 8%
Estimate against measurement, compound 3: 5 percentage points below, and the stated range covers the measured number.
By their numbers in this assay, from the lowest: compounds 1, 2 and 3 (each within the scatter of the next).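

In this assay, pyridin-4-yl in place of phenyl next to the ring nitrogen gives a number 0.9 percentage points higher from compound 2 to compound 3 (within the scatter) and 4-chlorophenyl in place of 3-chlorophenyl gives a number 8 percentage points higher from compound 1 to compound 3 (within the scatter) as a one-place comparison. Neither swap separates from the scatter, so neither the phenyl-to-pyridin-4-yl exchange nor the shift of the chloro group has a readable effect on this shared core at the one concentration tested.

Going by these compounds, whether an amine or a carboxylic acid on the core, or a longer chain in place of pyridin-4-yl, would give a reading beyond the scatter remains open. Nothing further is available that bears on these readings.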